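Adding a sulfamoyl chain to compound 2

The source may report more compounds than this note shows. Statements on the series, on what has been measured and on what is new or still open speak of the compounds shown alone.

Measured in a functional assay on GC3/MTK- cells (Homo sapiens) for inhibition; a higher number here means a weaker inhibitor, a lower number a stronger inhibitor:
- Compound 1 `C#CCN(Cc1ccc2nc(C)nc(O)c2c1)c1cccc(C(C)O)c1`: 49000 nM
- Compound 2 `C#CCN(Cc1ccc2nc(C)nc(O)c2c1)c1cccc(C(F)(F)F)c1`: > 4300 nM

For compound 2, > 4300 nM is a limit and not a number. the limit of > 4300 nM in this assay, at which 1 of the 2 values shown sits, is all that fixes its standing. Compound 3 `C#CCN(Cc1ccc2nc(C)nc(O)c2c1)c1ccc(S(=O)(=O)NCC(=O)O)c(C(F)(F)F)c1` carries (carboxymethyl)sulfamoyl in place of hydrogen on an aromatic carbon, ortho to the trifluoromethyl group and para to a large group ((carboxymethyl)sulfamoyl in place of hydrogen on an aromatic carbon). Among the compounds with values here, the one measured step, a step that the limit leaves unreadable from compound 1 to compound 2, concerns another change and gives no size to carry over. Within the data shown here, the only firm number is that of compound 1, at 49000 nM, so weak inhibition is expected. The expected change is a step that the limit leaves unreadable from compound 2 to compound 3. Compound 3 is estimated at 20000 nM, within 3000 nM to 100000 nM.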

Compound 3, half-maximal inhibitory concentration: > 77000 nM
Compound 3 was reported as a limit; the forecaster's own chance of this, stated with the estimate: 35%; middle value at least 3.8-fold (0.58 log units) from the limit.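

Within the data shown here, compound 2 and compound 3 are each reported only as a limit, and no step between them can be read. From the compounds shown here alone, whether (carboxymethyl)sulfamoyl in place of hydrogen strengthens or weakens inhibition in this assay remains open.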